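A Chloro Step Repeated on a Second Core

The compounds below may be only part of what the source reports. "The series", "measured", "known", "first", "only" and "open" are said of these compounds alone.

compound 1, `COc1ccccc1S(=O)(=O)/C=C/c1ccccn1`: 9070 nM
compound 2, `COc1ccccc1S(=O)(=O)/C=C/c1ccc(Cl)cn1`: 6310 nM
compound 3, `COc1ccc(S(=O)(=O)/C=C/c2ccccn2)cc1`: > 10000 nM

In an assay on U2OS cells for activation of nuclear factor erythroid 2-related factor 2 (Homo sapiens), read by chemiluminescence, with a stated time of 6 h (on this read-out lower numbers stand for an effect already at smaller amounts and higher numbers for an effect only at larger amounts of compound), compound 1 gives 9070 nM and compound 2 gives 6310 nM. The change between them is chloro in place of hydrogen on an aromatic carbon, and it produced a 1.4-fold lower number from compound 1 to compound 2 (0.16 log units; within the scatter). Compound 3 holds the same atoms as compound 1 joined differently; the difference between the two cores is not broken down here. For compound 3 the result in this assay is only a limit, > 10000 nM, because it sits at the limit of > 10000 nM in this assay, at which 1 of the 3 values shown sits. Compound 4, `COc1ccc(S(=O)(=O)/C=C/c2ccc(Cl)cn2)cc1`, has not been measured in this assay. Among the compounds with values here, it carries chloro in place of hydrogen on an aromatic carbon, the same change as the one from compound 1 to compound 2, at the same place. The step is expected to be a step that the limit leaves unreadable from compound 3 to compound 4, set beside the earlier step, resting on that step being within the scatter and on compound 3 giving only a limit. Compound 4 is therefore estimated at 12000 nM in this assay, expected between 5000 nM and 30000 nM, with a real chance that only a limit is reported again.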

Compound 4, half-maximal effective concentration: 9360 nM
Estimate against measurement, compound 4: 1.3-fold (0.11 log units) above; low and high end bracket the measured number.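

In this assay compound 3 gives > 10000 nM, which is a limit of the assay and not a number. Chloro in place of hydrogen on an aromatic carbon comes out as an at least 1.0-fold lower number from compound 3 to compound 4 (0.02 log units; that floor lies within the scatter), and beside the same change on the core of compound 1 this can be read only so far: the same change on two cores in this assay, a 1.4-fold lower number (0.16 log units; within the scatter) from compound 1 to compound 2 and an at least 1.0-fold lower number (0.02 log units; that floor lies within the scatter) from compound 3 to compound 4; the limit leaves it open whether they differ The account therefore shows no step beyond the scatter on either core, but only the floor of the step is known on the second core, so it does not show that the change carries over with the same size, nor that it does nothing there.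

The compounds shown leave open what another group would do on that aromatic carbon, two atoms from the ring nitrogen, for instance an amine, a carboxylic acid or a longer chain in place of the chloro. They also leave open whether any such group on the core of compound 3 would give a step that could be read in full in this assay.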